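From isobutoxy to cyclopropylmethoxy: working notes

This account rests on a few compounds, and the source may have more. Where it says the series, first, only, none or still open, it means among the compounds named here.

All values in this series come from a physicochemical assay for lipophilicity, using the shake flask method, in phosphate buffer, measured as octanol-water partition, with a stated time of 24 h, at pH 7.4, tested at 100 uM; a higher number here means a more lipophilic compound, a lower number a more polar compound. Compound 1 `Cc1cccc(C)c1-c1cccc(COc2ccc(S(=O)(=O)CC(=O)O)cc2)c1`, with hydrogen at the place of substitution, gives 2.49. Compound 2 `CCCOc1cc(C)c(-c2cccc(COc3ccc(S(=O)(=O)CC(=O)O)cc3)c2)c(C)c1`, carrying propoxy, gives 3.58. Compound 3 `Cc1cc(OCC(C)C)cc(C)c1-c1cccc(COc2ccc(S(=O)(=O)CC(=O)O)cc2)c1`, carrying isobutoxy, gives 3.94, the highest of the three numbers, and its gaps to both others lie beyond the scatter.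

Compound 4 `Cc1cc(OCC2CC2)cc(C)c1-c1cccc(COc2ccc(S(=O)(=O)CC(=O)O)cc2)c1` departs from compound 3 in one place, isobutoxy to cyclopropylmethoxy: cyclopropyl in place of isopropyl on a saturated chain carbon bound to an oxygen on an aromatic ring. Going by the values given here, no measured step places a ring in this chain, so the evidence is indirect. Propoxy in place of hydrogen gives a number 1.09 log units higher from compound 1 to compound 2 (beyond the scatter), and isobutoxy in place of hydrogen gives a number 1.45 log units higher from compound 1 to compound 3 (beyond the scatter). These large steps show how much the ether chain as a whole can move the number, but compound 4 keeps such a chain. The nearer guide is the chain change alone, where methyl in place of hydrogen gives a number 0.36 log units higher from compound 2 to compound 3 (beyond the scatter). A step of similar modest size, in the downward direction, is therefore expected here, with a number 0.34 log units lower from compound 3 to compound 4 (beyond the scatter) as the estimated change. Compound 4 is estimated at 3.6, with an expected range from 3.3 to 3.95.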

Compound 4, distribution coefficient: 3.46
For compound 4 the middle estimate is 0.14 log units above the measured one, within the range that was stated.
By their numbers in this assay, from the lowest: compound 1; then compounds 4 and 2 (each within the scatter of the next); then compound 3.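

Within this assay, the isopropyl and cyclopropyl ends both hold 3 carbon heavy atoms, yet closing the three-membered ring on the saturated chain carbon bound to an oxygen on an aromatic ring still gives a measurable step (a number 0.48 log units lower from compound 3 to compound 4 (beyond the scatter)), so at this position the number follows the form of the chain end and not just its heavy-atom count. Compound 2 and compound 4 cannot be separated on this read-out (a number 0.12 log units lower from compound 2 to compound 4 (within the scatter)), which places the open propoxy chain and the cyclopropylmethoxy group level within the scatter, while the isobutoxy group of compound 3 stands clear of both. Set against the unsubstituted parent, the cyclopropylmethoxy group nevertheless remains a clear gain (a number 0.97 log units higher from compound 1 to compound 4 (beyond the scatter)), so the ring trims the rise from the ether chain without removing it.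

As far as these compounds go, whether a cyclobutyl end, a longer chain or an amine on the same ether would follow this pattern remains open, as three chains at a single position cannot define a trend. No evidence bearing on the cause of the step from isopropyl to cyclopropyl is available.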